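Urea nitrogen substituent exchange on the shared core

The source may report more compounds than this note shows. Statements on the series, on what has been measured and on what is new or still open speak of the compounds shown alone.

Measured compounds in a functional assay on U-87MG ATCC cells for cytotoxicity against U-87 MG (Homo sapiens), read by MTT assay, with a stated time of 72 h; on this read-out lower numbers stand for stronger inhibition and higher numbers for weaker inhibition:
compound 1 `COc1ncc(-c2ccc3nc(NC(=O)NCCN4CCCC4)nn3c2)cc1NS(=O)(=O)c1ccc(F)cc1` gives 1120 nM
compound 2 `COc1ncc(-c2ccc3nc(NC(=O)NC4CC4)nn3c2)cc1NS(=O)(=O)c1ccc(F)cc1` gives 540 nM
compound 3 `CCN(CC)CCNC(=O)Nc1nc2ccc(-c3cnc(OC)c(NS(=O)(=O)c4ccc(C)cc4)c3)cn2n1` gives 670 nM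

Compound 2 has the lowest number of the three, but compound 3 lies within the scatter of it, so no order between those two can be stated. Among the compounds with values here, compound 1 stands beyond the scatter: the single one-place step, a 2.1-fold lower number from compound 1 to compound 2 (0.32 log units; beyond the scatter), is the only comparison of this kind so far.

Compound 4 `COc1ncc(-c2ccc3nc(NC(=O)NCCN4CCN(C)CC4)nn3c2)cc1NS(=O)(=O)c1ccc(F)cc1` is the next candidate; it differs from compound 2 as 2-(4-methylpiperazin-1-yl)ethyl in place of cyclopropyl on an amide-type nitrogen. The step from compound 1 to compound 2 is the one that bears on this change, since there too a two-carbon chain ending in a saturated nitrogen ring left and cyclopropyl entered; run in reverse, it suggests a modest rise in the number. Compound 3, carrying a different chain of this type together with a different sulfonyl aryl group, offers no clean one-place comparison and is noted only for its value. Compound 4 is therefore expected to give 1000 nM, in the range 450 nM to 2200 nM. This corresponds to an expected step of a 1.9-fold higher number from compound 2 to compound 4 (0.27 log units; within the scatter).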

Compound 4, half-maximal inhibitory concentration: 760 nM
Compound 4: the middle estimate sits 1.3-fold (0.12 log units) above what was measured, and the stated range covers the measured number.
By their numbers in this assay, from the lowest: compounds 2, 3, 4 and 1 (each within the scatter of the next, the first and the last beyond it).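

In this assay, 2-(4-methylpiperazin-1-yl)ethyl in place of cyclopropyl on the amide-type nitrogen gives a 1.4-fold higher number from compound 2 to compound 4 (0.15 log units; within the scatter), so this substituent, with its added ring and two nitrogens, is not separated from cyclopropyl here. The chain-end exchange, 4-methylpiperazin-1-yl in place of pyrrolidin-1-yl, gives a 1.5-fold lower number from compound 1 to compound 4 (0.17 log units; within the scatter), so compound 4 is separated from neither compound 1 nor compound 2, although those two stand apart beyond the scatter. No accompanying measurement accounts for these differences at this position.

Still open, on these data alone, is how a morpholin-4-yl group at the chain end, or a longer chain carrying the same piperazine, would read on this assay. Compound 3 differs from the others in more than one place, so the sulfonyl aryl group remains unresolved.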